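Swapping the ring at the end of the chain in compound 3

The compounds below may be only part of what the source reports. "The series", "measured", "known", "first", "only" and "open" are said of these compounds alone.

Of the compounds shown here, three sharing one core have been measured in an assay on isolated protein for inhibition of Amine oxidase [flavin-containing] A (Homo sapiens), read by fluorescence; a lower number here means a stronger inhibitor, a higher number a weaker inhibitor. Compound 1 `O=C(/C=C/c1nccs1)c1cc(O)c(O)c([N+](=O)[O-])c1` gives 69600 nM. Compound 2 `O=C(/C=C/c1cccc(O)c1)c1cc(O)c(O)c([N+](=O)[O-])c1` gives 43900 nM. Compound 3 `O=C(/C=C/c1cccs1)c1cc(O)c(O)c([N+](=O)[O-])c1` gives 49900 nM. Among these three numbers compound 3 stands second highest, with compound 2 nearest and compound 1 furthest, both within the scatter of it.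

Compound 4 `Cn1cc(/C=C/C(=O)c2cc(O)c(O)c([N+](=O)[O-])c2)cn1` differs from compound 3 in one place: 1-methyl-1H-pyrazol-4-yl in place of thiophen-2-yl on a double-bonded chain carbon bound to a double-bonded chain carbon. Among the measured compounds shown here, two measured steps bear on this kind of swap, each replacing the ring on the double-bonded chain carbon: a 1.4-fold lower number from compound 1 to compound 3 (0.14 log units; within the scatter) and a 1.1-fold higher number from compound 2 to compound 3 (0.06 log units; within the scatter). Both stayed within the scatter, so exchanging one small aromatic ring for another at this position has so far made no difference that can be told from repeat measurements. A step of the same size, none beyond the scatter, is therefore expected for compound 4 in this assay.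

For compound 4 the expected value in this assay is 58000 nM, with a range from 25000 nM to 140000 nM. The step this estimate implies, a 1.2-fold higher number from compound 3 to compound 4 (0.07 log units; within the scatter), is expected to stay within the scatter.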

Compound 4, half-maximal inhibitory concentration: 51500 nM
Compound 4: the middle estimate sits 1.1-fold (0.05 log units) above what was measured; measured number inside the range.
By their numbers in this assay, from the lowest: compounds 2, 3, 4 and 1 (each within the scatter of the next).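

Placing 1-methyl-1H-pyrazol-4-yl on the double-bonded chain carbon brings in a ring with 2 hetero atoms, both nitrogen, and a methyl group, yet in this assay the steps are a 1.0-fold higher number from compound 3 to compound 4 (0.01 log units; within the scatter), a 1.2-fold higher number from compound 2 to compound 4 (0.07 log units; within the scatter) and a 1.4-fold lower number from compound 1 to compound 4 (0.13 log units; within the scatter). The flat picture therefore extends to a ring without sulfur that carries a methyl group, and none of the four compounds can be told apart at this position. Nothing shown here explains why the number stays put.

Still open, going by these compounds, is whether anything other than a small aromatic ring would move the number, such as a saturated cyclohexyl ring or a phenyl ring carrying a carboxylic acid or an amine. The compounds shown also leave open whether a longer chain between the carbonyl and the ring would matter.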